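One more methyl on the nitrogen

This account rests on a few compounds, and the source may have more. Where it says the series, first, only, none or still open, it means among the compounds named here.

In a functional assay on A549 cells (Homo sapiens) for antiproliferative activity, read by MTT assay, with a stated time of 72 h (on this read-out higher numbers stand for weaker inhibition and lower numbers for stronger inhibition), compound 1 `CNc1nc(-c2cc(OC)c(OC)c(OC)c2)c(-c2ccc(C)cc2)s1` gives 125 nM and compound 2 `CCOc1ccc(-c2sc(NC)nc2-c2cc(OC)c(OC)c(OC)c2)cc1` gives 38.6 nM, the lower of the two numbers and so the stronger inhibition. Compound 3 `CCOc1ccc(-c2sc(N(C)C)nc2-c2cc(OC)c(OC)c(OC)c2)cc1` differs from compound 2 in one place: methyl in place of hydrogen on a nitrogen on an aromatic ring. This is methyl in place of hydrogen on a nitrogen on an aromatic ring, turning methylamino into dimethylamino. Among the compounds with values here, the only measured step, a 3.2-fold lower number from compound 1 to compound 2 (0.51 log units; beyond the scatter), swaps methyl for ethoxy on an aromatic carbon, elsewhere in the molecule. Within the data shown here, it therefore shows only how large one small change can be, and no measured pair tests the nitrogen. A step of similar size towards a higher number is a cautious expectation, with the direction uncertain. The expected change is a 3.1-fold higher number from compound 2 to compound 3 (0.49 log units; beyond the scatter). For compound 3 the estimated value is 120 nM, with an expected range from 30 nM to 500 nM.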

Compound 3, half-maximal inhibitory concentration: > 10000 nM
Compound 3: a limit, no number (the forecaster's own chance of this, stated with the estimate: 2%); middle value at least 83-fold (1.92 log units) away from the limit.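

In this assay, within the data shown here, this nitrogen turns out to be far less tolerant than the earlier compounds could show: one added methyl, turning methylamino into dimethylamino, gives an at least 250-fold higher number from compound 2 to compound 3 (2.41 log units; beyond the scatter). That step is large, whereas a 3.2-fold lower number from compound 1 to compound 2 (0.51 log units; beyond the scatter), made elsewhere in the molecule, is modest. Compound 3 sits at a limit and not at a number, so the full size of the step stays unknown: the limit of > 10000 nM in this assay, at which 1 of the 3 values shown sits.

The compounds shown leave open whether the loss of the hydrogen or the arrival of the methyl matters here, and whether a plain amino group or ethylamino on this carbon of the ring would behave like compound 2 or like compound 3. They also leave open whether dimethylamino would cost as much with methyl in place of ethoxy, as in compound 1.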